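Moving a Chlorine Atom Along a Benzyl Ring

A few compounds are considered here, and "the series" means these few. Any claim that something is new, unique, unknown or untested is made for them only; others in the source may bear on it.

Compound 1, `CC1=C(C(=O)Nc2ccc([N+](=O)[O-])cc2)C(c2ccc(Br)cc2)N=C(SCc2ccccc2Cl)N1`, gives 6.7% in a functional assay on the whole organism (artery, strain albino) with Rattus norvegicus as the target, with a stated time of 720 min, at a dose of 10 mg/kg by the oral route; on this read-out higher numbers stand for more inhibition at the one dose given (going by the name of the read-out) and lower numbers for less inhibition.
Compound 2, `CC1=C(C(=O)Nc2ccc([N+](=O)[O-])cc2)C(c2ccc(Br)cc2)N=C(SCc2cccc(Cl)c2)N1`, gives 2.6% in this assay.
Compound 3, `CC1=C(C(=O)Nc2ccc([N+](=O)[O-])cc2)C(c2cccc([N+](=O)[O-])c2)N=C(SCc2ccccc2Cl)N1`, gives 11.3% in this assay.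

The three measured compounds share one core and differ at two places. The step of a number 4.1 percentage points lower from compound 1 to compound 2 (within the scatter) belongs to the change (3-chlorophenyl in place of 2-chlorophenyl on a saturated chain carbon bound to a sulfur). The step of a number 4.6 percentage points higher from compound 1 to compound 3 (within the scatter) belongs to the change (3-nitrophenyl in place of 4-bromophenyl on a saturated ring carbon), which is also how the core of compound 3 differs from that of compound 1. Compound 4, `CC1=C(C(=O)Nc2ccc([N+](=O)[O-])cc2)C(c2cccc([N+](=O)[O-])c2)N=C(SCc2cccc(Cl)c2)N1`, has not yet been tested in this assay. It differs from compound 3 by 3-chlorophenyl in place of 2-chlorophenyl on a saturated chain carbon bound to a sulfur, the same change as from compound 1 to compound 2, now made on the core of compound 3. The place of the change reads the same in both pairs. In this assay the step from compound 3 to compound 4 is expected to be a number 4.3 percentage points lower from compound 3 to compound 4 (within the scatter), set beside the earlier a number 4.1 percentage points lower from compound 1 to compound 2 (within the scatter), because the earlier step of a number 4.1 percentage points lower from compound 1 to compound 2 (within the scatter) stayed within the scatter and the only difference is the core, whose own step a number 4.6 percentage points higher from compound 1 to compound 3 (within the scatter) also stayed within the scatter. Compound 4 is therefore estimated at 7%, with a likely range from 0% to 17%.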

Compound 4, a percentage reported as inhibition, in the whole organism at one dose (the size of the read-out at that dose, not a potency): 12.9%
Estimate against measurement, compound 4: 5.9 percentage points below; measured number inside the range.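

Moving the chlorine from 2-chlorobenzyl to 3-chlorobenzyl on the core of compound 3 gives a number 1.6 percentage points higher from compound 3 to compound 4 (within the scatter) in this assay, and this step does not differ from the one seen earlier on the core of compound 1: the same change on two cores in this assay, a number 4.1 percentage points lower (within the scatter) from compound 1 to compound 2 and a number 1.6 percentage points higher (within the scatter) from compound 3 to compound 4, 5.7 percentage points apart, within the scatter of two such steps
Replacing 4-bromophenyl with 3-nitrophenyl on a saturated ring carbon gives a number 10.3 percentage points higher from compound 2 to compound 4 (beyond the scatter), and although this step passes the scatter while its earlier counterpart did not, the two steps do not differ from each other: the same change on two cores in this assay, a number 4.6 percentage points higher (within the scatter) from compound 1 to compound 3 and a number 10.3 percentage points higher (beyond the scatter) from compound 2 to compound 4, 5.7 percentage points apart, within the scatter of two such steps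
So both changes carry from one core to the other as far as this small set can tell, but that does not show that their sizes are equal, and with both chlorine steps within the scatter, it does not show that moving the chlorine has any effect at all.

The compounds shown leave open what would happen if an amine or a carboxylic acid took the place of the chlorine on the benzyl ring. They also leave open whether a longer chain between the sulfur and the chlorophenyl ring would change either step.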